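Fluoro to Methoxy Swapped on Two Related Cores

The source may report more compounds than this note shows. Statements on the series, on what has been measured and on what is new or still open speak of the compounds shown alone.

Of the compounds shown here, three have been measured in a functional assay on HeLa cells (Homo sapiens) for cytotoxicity, read by MTT assay, with a stated time of 2 days, tested at 0.1 uM; a lower number here means a stronger effect, a higher number a weaker effect of the compound at the concentration tested. Compound 1 `CC(=O)c1cc(-c2ccc(F)cc2)cc2cc(-c3ccccc3)[nH]c12` gives 90.3%, compound 2 `COc1ccc(-c2cc(C(C)=O)c3[nH]c(-c4ccccc4)cc3c2)cc1` gives 87.9%, and compound 3 `CC(=O)c1cc(-c2ccccc2)cc2cc(-c3ccc(F)cc3)[nH]c12` gives 91.1%. Compound 2 arises from compound 1 by methoxy in place of fluoro on an aromatic carbon, a change that gave a number 2.4 percentage points lower from compound 1 to compound 2 (within the scatter). Compound 3 is built from the same atoms as compound 1 joined differently; the difference between the two cores is not broken down here. Compound 3 holds the highest of the three numbers, yet every gap among them falls within the scatter. Compound 4 `COc1ccc(-c2cc3cc(-c4ccccc4)cc(C(C)=O)c3[nH]2)cc1`, not yet measured, differs from compound 3 by methoxy in place of fluoro on an aromatic carbon, the same change as that from compound 1 to compound 2. The expected step to compound 4 in this assay is a number 2.4 percentage points lower from compound 3 to compound 4 (within the scatter), a step within the scatter. Compound 4 is thus estimated at 88.7%, between 82% and 95%, because the earlier change gave a number 2.4 percentage points lower from compound 1 to compound 2 (within the scatter).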

Compound 4, a percentage reported as activity, at one concentration (the size of the read-out at that concentration, not a potency): 80.5%
For compound 4 the middle estimate is 8.2 percentage points above the measured one; measured number outside the range, below it.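

In this assay, methoxy in place of fluoro gave a number 10.6 percentage points lower from compound 3 to compound 4 (beyond the scatter). Set beside the same change on the other core, this larger step cannot be told apart from the earlier one: the same change on two cores in this assay, a number 2.4 percentage points lower (within the scatter) from compound 1 to compound 2 and a number 10.6 percentage points lower (beyond the scatter) from compound 3 to compound 4, 8.2 percentage points apart, within the scatter of two such steps The result therefore does not show that the core alters the effect of this change, nor does it establish that the change carries over at one fixed size, with only a single pair on each core to compare.

The compounds shown leave open what an amine, a carboxylic acid or a longer alkoxy chain in place of the fluoro or methoxy group would give on either core. Each reading also comes from one concentration, so it tells only of a stronger or weaker effect at that concentration.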